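A few compounds are considered here, and "the series" means these few. Any claim that something is new, unique, unknown or untested is made for them only; others in the source may bear on it.

Compound 2, `Cc1ccc(OCC(=O)N(Cc2cccs2)c2ccn(C)n2)cc1`, belongs to a small set of amides built around a 4-methylphenoxy acetamide with a thiophen-2-ylmethyl group on the nitrogen, and in an assay on HEK293 cells for agonist activity at transient receptor potential cation channel subfamily M member 8 (Homo sapiens), read by fluorescence and calcium flux, with a stated time of 15 min (on this read-out higher numbers stand for an effect only at larger amounts of compound and lower numbers for an effect already at smaller amounts), compound 2 gives 855 nM. Its nearest neighbour by value is compound 1, `CCN(Cc1cccs1)C(=O)C(C)Oc1ccc(C)cc1`, which carries an ethyl group and a methyl-branched chain in place of the heteroaryl substituent; in this assay compound 1 gives 889 nM, a number that sits within the usual scatter of that of compound 2, so the two cannot be ordered against each other. A third member, compound 3, `CCN1C(=O)C(Oc2ccc(C)cc2)C1c1cccs1`, folds the same elements into a lactam, and in this assay compound 3 was reported as "active" (no number reported), without a number.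

Compound 4, `CCCN(Cc1cccs1)C(=O)COc1ccc(C)cc1`, has not yet been measured in this assay. It differs from compound 2 in a single place: propyl in place of 1-methyl-1H-pyrazol-3-yl on an amide-type nitrogen. Among the compounds with values here, no measured pair in the set isolates exactly this change. The closest guide is compound 1, whose small alkyl group on the same nitrogen gives 889 nM, essentially matching compound 2. On that basis only a step of little or no size beyond the scatter is expected from compound 2 to compound 4, in no clear direction, as a 1.1-fold higher number from compound 2 to compound 4 (0.02 log units; within the scatter). Compound 4 is therefore estimated at 900 nM, with a range from 300 nM to 3000 nM.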

Compound 4, half-maximal effective concentration: 40 nM
Beside the measured number, compound 4's estimate is 23-fold (1.35 log units) above it; the measured number lies below the stated range.
By their numbers in this assay, from the lowest: compound 4; then compounds 2 and 1 (each within the scatter of the next).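

In this assay the amide-type nitrogen of the shared core proves to be a sensitive position: propyl in place of 1-methyl-1H-pyrazol-3-yl brings a 21-fold lower number from compound 2 to compound 4 (1.33 log units; beyond the scatter) and thus a step well beyond the scatter. The closeness of the numbers for compound 1 and compound 2 could not show this, as those two differ in more than one place, whereas this pair isolates the substituent on that nitrogen alone. The change takes away the aromatic ring and its hydrogen-bond acceptors and brings in a plain alkyl chain all at once, and nothing available here bears on which of these differences accounts for the step.

With a single step at this nitrogen, the compounds shown do not tell whether the low number belongs to propyl in particular or would be shared by other alkyl groups on the same core, such as ethyl, isopropyl or a longer chain like butyl. They also leave open how a different ring on this nitrogen, such as phenyl, or a chain ending in an amine or a carboxylic acid would read.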